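The source may report more compounds than this note shows. Statements on the series, on what has been measured and on what is new or still open speak of the compounds shown alone.

Measured so far:
Compound 1, `N=C(N)c1ccc(C(=O)N2CCC3(CCN(C(=O)CCCCC(=O)O)CC3)CC2)cc1`, gives 18800 nM in a functional assay for inhibition, with Homo sapiens as the target; on this read-out higher numbers stand for weaker inhibition and lower numbers for stronger inhibition.
Compound 2, `N=C(N)c1ccc(C(=O)N2CCC3(CCN(C(=O)CCCC(=O)O)CC3)CC2)cc1`, gives 10300 nM in this assay.
Compound 3, `O=C(O)CCCC(=O)N1CCC2(CC1)CCN(c1ccncc1)CC2`, gives 5080 nM in this assay.

Compounds 1 and 2 share one core, while compound 3 is built on another; the difference between the two cores is not broken down here. Going from compound 2 to compound 1, the change is carboxymethyl in place of carboxy on a saturated chain carbon, three bonds along the chain from a carbonyl carbon, and in this assay it made a 1.8-fold higher number from compound 2 to compound 1 (0.26 log units; within the scatter). Compound 4, `O=C(O)CCCCC(=O)N1CCC2(CC1)CCN(c1ccncc1)CC2`, has not yet been measured and differs from compound 3 by carboxymethyl in place of carboxy on a saturated chain carbon, three bonds along the chain from a carbonyl carbon, the same change at the same kind of place. Compound 4 is therefore expected to show a step of a 1.7-fold higher number from compound 3 to compound 4 (0.22 log units; within the scatter) in this assay, close to the earlier one, because the same change gave a 1.8-fold higher number from compound 2 to compound 1 (0.26 log units; within the scatter). For compound 4 the estimate in this assay is 8500 nM, with a likely range from 3500 nM to 22000 nM.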

Compound 4, half-maximal inhibitory concentration: 4540 nM
Compound 4: the middle estimate sits 1.9-fold (0.27 log units) above what was measured, and the stated range covers the measured number.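

In this assay, putting carboxymethyl in place of carboxy on a saturated chain carbon, three bonds along the chain from a carbonyl carbon, gave a 1.1-fold lower number from compound 3 to compound 4 (0.05 log units; within the scatter). Set beside the earlier step, the change behaves alike on the two cores as far as this read-out can tell: the same change on two cores in this assay, a 1.8-fold higher number (0.26 log units; within the scatter) from compound 2 to compound 1 and a 1.1-fold lower number (0.05 log units; within the scatter) from compound 3 to compound 4, 2.0-fold (0.31 log units) apart, within the scatter of two such steps. This is no proof of a shared effect, however: neither step alone stands clear of the scatter, and two pairs are a small sample.

The compounds shown leave open whether a longer chain, such as 3-carboxypropyl or 4-carboxybutyl, would shift the number beyond the scatter. They also leave open what an amine or a primary amide would do in place of the carboxylic acid.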